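A few compounds are considered here, and "the series" means these few. Any claim that something is new, unique, unknown or untested is made for them only; others in the source may bear on it.

Compound 1 `CN(C)c1ncnc2c1ncn2Cc1ccc(Cl)cc1` — 0%
Compound 2 `CC(C)N(C)c1ncnc2c1ncn2CC1CC1` — 32%
Compound 3 `CCN(CC)c1ncnc2c1ncn2CC1CC1` — 0%

All three numbers come from a functional assay on the whole organism for inhibition, with Rattus norvegicus as the target, at a dose of 25 mg/kg by the intraperitoneal route; on this read-out higher numbers stand for more inhibition at the one dose given (going by the name of the read-out) and lower numbers for less inhibition. Compound 3 stands level with compound 1 at the digits shown, and the two together are the lowest of the three; compound 2 lies furthest from it, as the step of a number 32 percentage points lower from compound 2 to compound 3 (beyond the scatter) shows. The step now taken goes from compound 3 to compound 4 `CCCNc1ncnc2c1ncn2CC1CC1`, in which (propylamino in place of diethylamino on an aromatic carbon). Going by the values given here, only one measured step touches the amino group on the shared core: a number 32 percentage points lower from compound 2 to compound 3 (beyond the scatter), a large drop when isopropyl(methyl)amino gives way to diethylamino. Among the compounds with values here, no measured pair shows propylamino, so that step guides only in showing that the amino group has moved the number once, and by a lot. In this assay compound 4 is therefore expected to land between the two levels seen so far. The step of a number 15 percentage points higher from compound 3 to compound 4 (beyond the scatter) is expected to be a small to moderate rise. Compound 4 is estimated at 15%, with a range from 0% to 40%.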

Compound 4, a percentage reported as inhibition, in the whole organism at one dose (the size of the read-out at that dose, not a potency): 0%
Compound 4: middle estimate off by 15 percentage points, on the high side; the range from low to high includes it.
By their numbers in this assay, from the lowest: compounds 1, 3 and 4 (each within the scatter of the next); then compound 2.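

In this assay, putting propylamino in place of diethylamino on this aromatic carbon gives no change at the digits printed from compound 3 to compound 4 (within the scatter), even though hydrogen-bond donors go from 0 to 1 in the change. Putting propylamino in place of isopropyl(methyl)amino gives a number 32 percentage points lower from compound 2 to compound 4 (beyond the scatter), so on this shared core isopropyl(methyl)amino now stands apart from two different amino groups, one with a hydrogen on its nitrogen and one without. Nothing measured here accounts for why this one group stands apart.

Still open, on these data alone, is whether the branched chain, the methyl on the nitrogen or the two together set that higher number, which isopropylamino on the same carbon would help to separate. As far as these compounds go, how a ring amine such as pyrrolidine would read at this position also remains open.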